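A Larger Group on the Ring Amine Nitrogen

The source may report more compounds than this note shows. Statements on the series, on what has been measured and on what is new or still open speak of the compounds shown alone.

Measured compounds:
compound 1 `Cc1ccccc1CN1CCc2c(sc(NC(=O)c3ccccc3Cl)c2C(N)=O)C1` — > 50000 nM
compound 2 `NC(=O)c1c(NC(=O)c2ccccc2F)sc2c1CCN(Cc1c(Cl)cccc1Cl)C2` — 33000 nM

Both were tested in a functional assay on HeLa cells (Homo sapiens) for antiproliferative activity, with a stated time of 24 h; a lower number here means a stronger inhibitor, a higher number a weaker inhibitor. For compound 1 the result is only a limit of the assay, > 50000 nM, which sits at the limit of > 50000 nM in this assay, at which 1 of the 2 values shown sits, so nothing more precise is known about it. Compound 2 gives 33000 nM, a weak result on its own. Compound 3 `Cc1ccccc1NC(=S)N1CCc2c(sc(NC(=O)c3ccccc3Cl)c2C(N)=O)C1` is built from compound 1 by one exchange: a group of 10 heavy atoms (8 carbon, 1 nitrogen, 1 sulfur; one six-membered aromatic ring of carbon only) in place of a group of 8 heavy atoms (8 carbon; one six-membered aromatic ring of carbon only), on an amine nitrogen in a ring. Within the data shown here, no pair of measured compounds that differ in a single place is available here, so there is no measured step of this kind to lean on. The step from compound 1 to compound 3 is therefore expected to be small, an at least 1.1-fold lower number from compound 1 to compound 3 (0.04 log units; that floor lies within the scatter), and not clearly beyond the scatter in either direction. Compound 3 is estimated at 45000 nM, within a range from 15000 nM to 150000 nM.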

Compound 3, half-maximal inhibitory concentration: > 50000 nM
Compound 3 gave a limit, no number (the forecaster's own chance of this, stated with the estimate: 55%); at least 1.1-fold (0.04 log units) between middle value and limit.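

Compound 1 and compound 3 each give only a limit of the assay, not a number, so no step between them can be read: the limit of > 50000 nM in this assay, at which 2 of the 3 values shown sit.

As far as these compounds go, whether exchanging the 2-methylbenzyl group on the ring amine nitrogen for the group in compound 3 changes the result in this assay stays open.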